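Fluoro to Methoxy at a Tolerant Spot

The source may report more compounds than this note shows. Statements on the series, on what has been measured and on what is new or still open speak of the compounds shown alone.

In a functional assay on QG-56 cells (Homo sapiens) for antiproliferative activity (on this read-out higher numbers stand for weaker inhibition and lower numbers for stronger inhibition), compound 1 `Cn1cncc1[C@@](N)(c1ccc(C#N)cc1)c1cc2cc(C#N)cc(-c3cccc(C#N)c3)c2o1` gives 2 nM as its reading. Among the compounds with values here, compound 2 `Cn1cncc1[C@@](N)(c1ccc(C#N)cc1)c1cc2cc(C#N)cc(-c3cccc(F)c3)c2o1` gives 2 nM in this assay and stands level with compound 1, its only measured neighbour. Compound 3 `COc1cccc(-c2cc(C#N)cc3cc([C@](N)(c4ccc(C#N)cc4)c4cncn4C)oc23)c1` is still unmeasured. It differs from compound 2 by one change, methoxy in place of fluoro on an aromatic carbon, which turns 3-fluorophenyl into 3-methoxyphenyl: methoxy in place of fluoro on an aromatic carbon is the full count. Within the data shown here, one measured step bears on this place, fluoro in place of cyano, and it shows no change at the digits printed from compound 1 to compound 2 (within the scatter) for that swap. Among the measured compounds shown here, that is a single step, and no methoxy compound has been tested, so the evidence is thin. The expected result is no shift beyond the scatter, with the estimated step being a 1.5-fold higher number from compound 2 to compound 3 (0.18 log units; within the scatter) in this assay on this reasoning. The estimate for compound 3 is 3 nM with an expected range from 1 nM to 8 nM in this assay for now.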

Compound 3, half-maximal inhibitory concentration: 1.5 nM
Compound 3: the middle estimate sits 2.0-fold (0.30 log units) above what was measured; the range from low to high includes it.
By their numbers in this assay, from the lowest: compounds 3, 1 and 2 (each within the scatter of the next).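

In this assay the swap to methoxy gives a 1.3-fold lower number from compound 2 to compound 3 (0.12 log units; within the scatter) and the swap from cyano to methoxy gives a 1.3-fold lower number from compound 1 to compound 3 (0.12 log units; within the scatter) at the same aromatic carbon, so this spot has now carried three different groups with readings that all lie within the scatter of one another. Methoxy brings two heavy atoms where fluoro had one, and one hydrogen-bond acceptor where fluoro had none, yet neither difference comes with a step beyond the scatter. Nothing available explains why these groups read alike.

As far as these compounds go, whether this aromatic carbon would also accept an amine, a carboxylic acid or a longer chain such as butoxy remains open. The compounds shown also leave open whether the same swaps would read alike elsewhere on the shared core.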